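A few compounds are considered here, and "the series" means these few. Any claim that something is new, unique, unknown or untested is made for them only; others in the source may bear on it.

Measured compounds:
compound 1 `Cc1cc(NCCN2CCN(C)CC2)nc2ccc(NC(=O)c3ccc(Cl)c(Cl)c3)cc12`: 1700 nM
compound 2 `CCN1CCN(c2cc(C)c3cc(NC(=O)c4cc(Cl)cc(Cl)c4)ccc3n2)CC1`: 6090 nM
compound 3 `CNc1cc(C)c2cc(NC(=O)c3ccc(Cl)c(Cl)c3)ccc2n1`: 2520 nM

All three were run in a functional assay on MCF7 cells (Homo sapiens) for antiproliferative activity, read by MTT assay, with a stated time of 72 h; on this read-out lower numbers stand for stronger inhibition and higher numbers for weaker inhibition. Compound 2 gives the highest number of the three; compound 3 is nearest and compound 1 furthest, and both gaps lie beyond the scatter. Going by the values given here, the one single-point step measured so far, a 1.5-fold higher number from compound 1 to compound 3 (0.17 log units; within the scatter), concerns the chain on the ring nitrogen of the shared core, not the amide end, and stays within the scatter.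

Compound 4 `CCN1CCN(c2cc(C)c3cc(NC(=O)c4ccccc4)ccc3n2)CC1` differs from compound 2 in one place: phenyl in place of 3,5-dichlorophenyl on a carbonyl carbon. Among the compounds with values here, no measured step touches the aryl group on the carbonyl carbon. Compounds 1 and 3 also carry a dichlorinated phenyl ring there, but they differ from compound 2 elsewhere as well, so their values give no clean reading of this change. With nothing to anchor it, the expected step is a 1.1-fold higher number from compound 2 to compound 4 (0.06 log units; within the scatter), which is no change beyond the scatter, with a wide range to either side. Compound 4 is estimated at 7000 nM, within 2500 nM to 25000 nM.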

Compound 4, half-maximal inhibitory concentration: 14200 nM
Estimate against measurement, compound 4: 2.0-fold (0.31 log units) below; low and high end bracket the measured number.
By their numbers in this assay, from the lowest: compounds 1 and 3 (each within the scatter of the next); then compound 2; then compound 4.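

The aryl group on the carbonyl carbon is not silent in this assay: with phenyl in place of 3,5-dichlorophenyl, the result is a 2.3-fold higher number from compound 2 to compound 4 (0.37 log units; beyond the scatter), so the two chlorines count for something at this position in the series. Going by these compounds alone, this is the first single-point step to lie beyond the scatter, whereas the only earlier one, a 1.5-fold higher number from compound 1 to compound 3 (0.17 log units; within the scatter), concerned the chain and not the amide end and stayed within it. No data bearing on the cause of this step are available.

Open, going by these compounds, is whether a single chlorine on the phenyl ring would read like compound 2 or like compound 4, and whether trifluoromethyl or methoxy could stand in for the chlorines. Also open, on these data alone, is whether losing the chlorines would give a step of similar size with the chains of compound 1 and compound 3.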